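Notes on aryl-ethenyl variation within one series

This account rests on a few compounds, and the source may have more. Where it says the series, first, only, none or still open, it means among the compounds named here.

Measured so far in an ADME assay on PANC-1 cells (Homo sapiens) for cytotoxicity, read by MTT assay, with a stated time of 48 h; on this read-out lower numbers stand for stronger inhibition of growth and higher numbers for weaker inhibition of growth:
compound 1, `COc1ccc(/C=C\C(=O)N2N=C(c3ccncc3)OC2c2c[nH]c3ccccc23)cc1`: > 30 ug/mL
compound 2, `O=C(/C=C\c1cccc(F)c1)N1N=C(c2ccncc2)OC1c1c[nH]c2ccccc12`: > 30 ug/mL
compound 3, `O=C(/C=C\c1cccc(Cl)c1)N1N=C(c2ccncc2)OC1c1c[nH]c2ccccc12`: > 30 ug/mL

Each of these three values is a limit of this assay and not a number. Compound 1 sits at that limit, > 30 ug/mL. Compound 2 likewise sits only at a limit, > 30 ug/mL. Compound 3 too gives only a limit, > 30 ug/mL. Compound 3 therefore stands nowhere distinguishable from the other two: all three values shown share one limit (the limit of > 30 ug/mL in this assay, at which 3 of the 3 values shown sit), and no ranking among them is possible. The three steps, a step that the two limits leave unreadable from compound 1 to compound 2, a step that the two limits leave unreadable from compound 1 to compound 3 and a step that the two limits leave unreadable from compound 2 to compound 3, are each unreadable, both ends being limits; their sizes cannot be stated.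

Compound 4, `O=C(/C=C/c1c(Cl)cccc1Cl)N1N=C(c2ccncc2)OC1c1c[nH]c2ccccc12`, is the next member. It differs from compound 3 by 2-(2,6-dichlorophenyl)ethenyl in place of 2-(3-chlorophenyl)ethenyl on a carbonyl carbon. Among the compounds with values here, none of the measured steps bear on a second chloro or on this change, since every measured step is unreadable; no direction can be drawn from them. Within the data shown here, the only guide is that every aryl-ethenyl variant so far has stayed at the limit, so compound 4 is expected to do the same, with an expected step that the limit leaves unreadable from compound 3 to compound 4 not beyond the scatter. Compound 4 is thus estimated at 40 ug/mL in this assay, within a range of 20 ug/mL to 100 ug/mL, most likely reported again as a limit.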

Compound 4, concentration for 50% growth inhibition: > 30 ug/mL
Compound 4 ended at the assay's limit; the forecaster's own chance of this, stated with the estimate: 80%; the middle value does not contradict the limit.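

Compound 4 joins compound 1, compound 2 and compound 3 at a single limit of this assay, so none of the steps to compound 4 can be read: the limit of > 30 ug/mL in this assay, at which 4 of the 4 values shown sit.

The compounds shown leave open how these four aryl-ethenyl variants rank, and whether any aryl-ethenyl group on the shared core gives a value that is a number rather than a limit.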